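A few compounds are considered here, and "the series" means these few. Any claim that something is new, unique, unknown or untested is made for them only; others in the source may bear on it.

The series shares a fused core carrying an N-phenyl isoxazolidine; three members have numbers in a functional assay on PC-3 cells (Homo sapiens) for inhibition, read by sulforhodamine B assay, with a stated time of 48 h (on this read-out lower numbers stand for stronger inhibition and higher numbers for weaker inhibition), so far. Compound 1 `O=c1c([C@@H]2C[C@H](c3ccccc3)ON2c2ccccc2)coc2cc(Cl)c(Cl)cc12` gives 32000 nM in this assay. Compound 3 `CCO[C@H]1C[C@@H](c2coc3ccc(C)cc3c2=O)N(c2ccccc2)O1` gives 39000 nM in this assay. Compound 2 `O=C1[C@H]2[C@H](ON(c3ccccc3)[C@@H]2c2coc3ccc(F)cc3c2=O)C(=O)N1c1ccccc1`, which carries the fused succinimide and a fluoro group on the aromatic ring, reaches only the limit of this assay, > 60000 nM, so no number is known for it and it stands at the limit of > 60000 nM in this assay, at which 1 of the 3 values shown sits. Within the measured set, compound 1 and compound 3 are within the scatter of each other, and there is no pair differing in one place from which a step could be read.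

Compound 4 `O=C1[C@H]2[C@H](ON(c3ccccc3)[C@@H]2c2coc3ccc(Br)cc3c2=O)C(=O)N1c1ccccc1` is the next member; it differs from compound 2 by bromo in place of fluoro on an aromatic carbon. Among the measured compounds shown here, no measured step of this kind exists here, so the expectation rests on compound 2 alone: a change within the scatter, in no particular direction, and most likely another limit. For compound 4 an inhibitory concentration of about 70000 nM is expected, in the range 25000 nM to 200000 nM, meaning an expected step that the limit leaves unreadable from compound 2 to compound 4.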

Compound 4, half-maximal inhibitory concentration: 13300 nM
For compound 4 the middle estimate is 5.3-fold (0.72 log units) above the measured one; measured number outside the range, below it.
By their numbers in this assay, from the lowest: compound 4; then compounds 1 and 3 (each within the scatter of the next). At a limit, above all of these: compound 2.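

Among the compounds shown here, the halogen on this aromatic carbon is the first place where a single change can be read: in this assay, bromo in place of fluoro gives an at least 4.5-fold lower number from compound 2 to compound 4 (0.65 log units; beyond the scatter). Compound 4 carries the fused succinimide and gives 13300 nM, so that group does not by itself rule out a measured number in the series. The step to compound 4 is a lower bound only, since compound 2 stands at a limit of the assay and has no number: the limit of > 60000 nM in this assay, at which 1 of the 4 values shown sits.

Open, going by these compounds, is whether a methoxy group or an amine on this same carbon would follow bromo or stay with fluoro at the limit. Also open, on these data alone, is whether bromo in place of another group would bring a comparable step in compounds without the fused succinimide.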